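The source may report more compounds than this note shows. Statements on the series, on what has been measured and on what is new or still open speak of the compounds shown alone.

Measured so far:
Compound 1, `Nc1ccc2cccc(OCCC(F)(F)F)c2n1`, gives 722 nM in an assay on cells with melanin-concentrating hormone receptor 1 (Homo sapiens) as the target, read by radioligand binding; a higher number here means a weaker inhibitor, a lower number a stronger inhibitor.
Compound 2, `CC(COC(C)(C)C)Oc1cccc2ccc(N)nc12`, gives 306 nM in this assay.
Compound 3, `Nc1ccc2cccc(OCC3CCCC3)c2n1`, gives 53 nM in this assay.

Among these three, compound 3 has the lowest number and is thus the strongest inhibitor; compound 2 stands nearest to it and compound 1 furthest, with both gaps beyond the scatter.

Compound 4, `CCCCCOc1cccc2ccc(N)nc12`, has not yet been measured in this assay. It differs from compound 3 in one place: butyl in place of cyclopentyl on a saturated chain carbon bound to an oxygen on an aromatic ring. Among the measured compounds shown here, the only measured step that changes this same group is a 14-fold lower number from compound 1 to compound 3 (1.13 log units; beyond the scatter), a large gain from a fluorinated chain to a ring, which shows that what sits on this oxygen can move the number a long way. For the measured compounds named here, no measured step exchanges a ring for an open chain, so there is no direct precedent. Compound 2, which carries an open, branched chain rather than a ring, gives a higher number than compound 3, but its chain also differs in other ways, so it offers only a loose hint that open chains may do somewhat less well here.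

Compound 4 is therefore expected to be a little weaker than compound 3, with an estimated step of a 2.1-fold higher number from compound 3 to compound 4 (0.32 log units; beyond the scatter). The estimate for compound 4 is 110 nM, expected to lie between 40 nM and 320 nM.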

Compound 4, half-maximal inhibitory concentration: 580 nM
The estimate for compound 4 lay 5.3-fold (0.72 log units) below the measured number; the measured number lies above the stated range.
By their numbers in this assay, from the lowest: compound 3; then compounds 2, 4 and 1 (each within the scatter of the next, the first and the last beyond it).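

Swapping cyclopentyl for butyl on the saturated chain carbon bound to the oxygen on the aromatic ring gives an 11-fold higher number from compound 3 to compound 4 (1.04 log units; beyond the scatter) in this assay. Neither group carries a hydrogen-bond donor or acceptor, so this step sets a ring against an open chain and shows that the two are far from interchangeable here. The second step, a 1.2-fold lower number from compound 1 to compound 4 (0.10 log units; within the scatter), lies within the scatter, so propyl and trifluoromethyl cannot be told apart in this series; the large gain in compound 3 therefore goes with the cyclopentyl ring, not simply with the loss of the fluorine atoms. Nothing beyond these numbers is available to explain why the ring matters so much.

Whether cyclopentyl is a particularly good ring remains open, as the compounds shown say nothing about a cyclobutyl, cyclohexyl or phenyl group on the same chain carbon. It also remains unclear whether the ring itself is needed, or whether an open but branched group such as 2-ethylbutyl, which comes closer to the spread of cyclopentylmethyl than pentyl does, would recover the lost strength.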